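Swapping Methoxy for Chloro on a Sulfonamide Imide

A few compounds are considered here, and "the series" means these few. Any claim that something is new, unique, unknown or untested is made for them only; others in the source may bear on it.

For the measured compounds named here, compound 1 `COc1ccc(C(=O)CC2CC(=O)N(c3ccc(S(N)(=O)=O)cc3)C2=O)cc1` gives 2100 nM in an assay on Sf21 cells for inhibition of cytochrome c oxidase subunit 2 (Homo sapiens), read by spectrophotometry, with a stated time of 5 min (a higher number here means a weaker inhibitor, a lower number a stronger inhibitor), the lowest of the two numbers measured so far. Compound 2 `CC(=O)CC1CC(=O)N(c2ccccc2)C1=O` gives 63900 nM in this assay, a gap to compound 1 that lies well beyond the scatter. Compound 3 `NS(=O)(=O)c1ccc(N2C(=O)CC(CC(=O)c3ccc(Cl)cc3)C2=O)cc1` has not yet been measured. It differs from compound 1 by a single change: chloro in place of methoxy on an aromatic carbon. Going by the values given here, with only one small swap in play, the step of a 1.2-fold higher number from compound 1 to compound 3 (0.08 log units; within the scatter) is expected to stay within the usual scatter, in no clear direction. Compound 3 is therefore estimated at about 2500 nM, with a range from 900 nM to 7000 nM.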

Compound 3, half-maximal inhibitory concentration: 6290 nM
For compound 3 the middle estimate is 2.5-fold (0.40 log units) below the measured one, within the range that was stated.
By their numbers in this assay, from the lowest: compound 1; then compound 3; then compound 2.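

In this assay the group para to a large group is not a silent spot: changing 4-methoxyphenyl to 4-chlorophenyl gives a 3.0-fold higher number from compound 1 to compound 3 (0.48 log units; beyond the scatter), a modest weakening. Of the two groups compared here, methoxy therefore gives the stronger inhibitor. No available measurement explains this step. Still open, on these data alone, is how an amine or a carboxylic acid at this position would compare with methoxy and chloro. A single pair also cannot show whether a longer chain, such as ethoxy, would keep the potency of compound 1.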